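Nitro analogue with an ethyl chain: working notes

The source may report more compounds than this note shows. Statements on the series, on what has been measured and on what is new or still open speak of the compounds shown alone.

Measured compounds in a functional assay on 4T1 cells (Homo sapiens) for cytotoxicity, read by MTT assay, with a stated time of 48 h; a lower number here means a stronger inhibitor, a higher number a weaker inhibitor:
compound 1 `CCn1c(/C=C2/C(=O)Nc3ccc(C)cc32)nc2ccccc21`, 39400 nM
compound 2 `Cn1c(/C=C2/C(=O)Nc3ccc([N+](=O)[O-])cc32)nc2ccccc21`, > 50000 nM
compound 3 `Cn1c(/C=C2/C(=O)Nc3ccc(Cl)cc32)nc2ccccc21`, 43600 nM

Compound 2 stands at the limit of this assay, a value of > 50000 nM, which is a limit and not a number; this is the limit of > 50000 nM in this assay, at which 1 of the 3 values shown sits. Compound 4 `CCn1c(/C=C2/C(=O)Nc3ccc([N+](=O)[O-])cc32)nc2ccccc21` differs from compound 2 by methyl in place of hydrogen on a saturated chain carbon bound to an aromatic nitrogen. Among the compounds with values here, the only measured step touching compound 2 is an at least 1.1-fold lower number from compound 2 to compound 3 (0.05 log units; that floor lies within the scatter), which concerns the aromatic substituent and not the chain. Compound 1 and compound 3, which carry an ethyl and a methyl chain but differ also in the aromatic group, show values within the scatter of each other. A step that the limit leaves unreadable from compound 2 to compound 4 is therefore expected, none beyond the scatter. Compound 4 is estimated at 55000 nM, between 30000 nM and 100000 nM.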

Compound 4, half-maximal inhibitory concentration: > 50000 nM
Compound 4: no number, only a limit (the forecaster's own chance of this, stated with the estimate: 60%); the middle value lies beyond the limit too.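

In this assay compound 4 sits at a limit and not a number, as compound 2 does: the limit of > 50000 nM in this assay, at which 2 of the 4 values shown sit.

Methyl in place of hydrogen on the saturated chain carbon therefore cannot be read in the nitro pair, and the step between the two limits has no size. With the ethyl chain held fixed, nitro in place of methyl on an aromatic carbon gives an at least 1.2-fold higher number from compound 1 to compound 4 (0.10 log units; that floor lies within the scatter), so this change is not resolved either.

Open, going by these compounds, is whether a longer chain such as propyl, or an amine in place of nitro on the aromatic carbon, would give a readable number in this assay.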